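This account rests on a few compounds, and the source may have more. Where it says the series, first, only, none or still open, it means among the compounds named here.

Among the measured compounds shown here, compound 1 `COc1ccc(/C=C/C(=O)c2ccc(Nc3cc(C)nc4nc(SCc5nc6ccccc6[nH]5)nn34)cc2)cc1F` is one of two compounds measured in a functional assay on SW-620 cells (Homo sapiens) for cytotoxicity, read by MTT assay, with stated times of 4 h and 72 h, tested at 2 uM (on this read-out lower numbers stand for stronger inhibition and higher numbers for weaker inhibition), and there compound 1 gives 140 nM, the higher of the two numbers. For the measured compounds named here, its partner, compound 2 `Cc1cc(Nc2ccc(C(=O)/C=C/c3ccc4ccccc4c3)cc2)n2nc(SCc3nc4ccccc4[nH]3)nc2n1`, gives 5 nM in this assay, and the single step between them, a 28-fold lower number from compound 1 to compound 2 (1.45 log units; beyond the scatter), comes from swapping the aryl group at the end of the double-bonded chain. Compound 3 `Cc1cc(Nc2ccc(C(=O)/C=C/c3ccccc3Cl)cc2)n2nc(SCc3nc4ccccc4[nH]3)nc2n1` differs from compound 1 at that same chain carbon, but by a different exchange: 2-chlorophenyl in place of 3-fluoro-4-methoxyphenyl on a double-bonded chain carbon bound to a double-bonded chain carbon. Going by the values given here, only the step to compound 2 bears on this change, and it shows that replacing the group on that chain carbon can move the number a long way downward; 2-chlorophenyl, however, is not naphthalen-2-yl, so the expected step in this assay is a 1.8-fold lower number from compound 1 to compound 3 (0.24 log units; within the scatter), modest and downward. Compound 3 is therefore estimated at 80 nM, with a range from 25 nM to 300 nM.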

Compound 3, half-maximal inhibitory concentration: 680 nM
Beside the measured number, compound 3's estimate is 8.5-fold (0.93 log units) below it; the measured number lies above the stated range.
By their numbers in this assay, from the lowest: compound 2; then compound 1; then compound 3.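

In this assay, among the compounds shown here, this chain carbon proves sensitive in both directions: the only earlier step here went downward, whereas 2-chlorophenyl in place of 3-fluoro-4-methoxyphenyl gives a 4.9-fold higher number from compound 1 to compound 3 (0.69 log units; beyond the scatter). Exchanging naphthalen-2-yl for 2-chlorophenyl gives a far larger change, a 140-fold higher number from compound 2 to compound 3 (2.13 log units; beyond the scatter), so the choice of aryl group at this one place spans a wide range of numbers, with compound 2 lowest and compound 3 highest. Nothing available explains why these groups differ so strongly.

Compound 1 and compound 3 differ in chlorine, fluorine and methoxy together, and the compounds shown do not separate what each contributes to the step. Also open, as far as these compounds go, is how a plain phenyl group or a morpholine on this chain carbon would read out.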